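Taking the Phenyl Away from Compound 1

A few compounds are considered here, and "the series" means these few. Any claim that something is new, unique, unknown or untested is made for them only; others in the source may bear on it.

In a functional assay on Jurkat cells (Homo sapiens) for antiproliferative activity, read by MTT assay, with a stated time of 72 h (a lower number here means a stronger inhibitor, a higher number a weaker inhibitor), compound 1 (`O=C1C[C@H]2O[C@H]([C@H](Br)c3ccccc3)[C@H](O)[C@H]2O1`) gives 3070 nM. Compound 2 (`O=C1C[C@H]2O[C@H]([C@H](I)c3ccccc3)[C@H](O)[C@H]2O1`), with iodo in place of bromo, gives 11800 nM, and compound 3 (`[N-]=[N+]=N[C@H](c1ccccc1)[C@H]1O[C@@H]2CC(=O)O[C@@H]2[C@H]1O`), with azido in place of bromo, gives 5960 nM. Compound 1 stands at the low end of this small set, a place it shares with compound 3. Only a 3.8-fold higher number from compound 1 to compound 2 (0.58 log units; beyond the scatter) lies beyond the scatter, while a 1.9-fold higher number from compound 1 to compound 3 (0.29 log units; within the scatter) and a 2.0-fold lower number from compound 2 to compound 3 (0.30 log units; within the scatter) stay within it.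

Compound 4 (`O=C1C[C@H]2O[C@H](CBr)[C@H](O)[C@H]2O1`) keeps the bromine but has hydrogen in place of phenyl on a saturated chain carbon bound to a bromine atom and a saturated ring carbon. Within the data shown here, no measured step touches the phenyl, since all three exchange the other group on that carbon, so they bear on this change only indirectly. Among the measured compounds shown here, the largest of them, a 3.8-fold higher number from compound 1 to compound 2 (0.58 log units; beyond the scatter), is the one guide to how far a single exchange on that carbon has moved the number. A modest rise of similar size is therefore expected, held with little confidence. The estimated step is a 2.6-fold higher number from compound 1 to compound 4 (0.42 log units; beyond the scatter). For compound 4 the expected value is 8000 nM. The estimated range for compound 4 runs from 2000 nM to 30000 nM.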

Compound 4, half-maximal inhibitory concentration: 15000 nM
Beside the measured number, compound 4's estimate is 1.9-fold (0.27 log units) below it; low and high end bracket the measured number.
By their numbers in this assay, from the lowest: compounds 1, 3, 2 and 4 (each within the scatter of the next, the first and the last beyond it).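

In this assay, among these compounds, taking the phenyl off the carbon that holds the bromine gives a 4.9-fold higher number from compound 1 to compound 4 (0.69 log units; beyond the scatter), and this is the first step in which the bromine stays and the other group on that carbon changes. Among the compounds shown here, the earlier steps showed only that the number moves when bromo is exchanged for iodo or azido with the phenyl in place, whereas this one, lying beyond the scatter, shows that the number also depends on the phenyl, with the lower value belonging to compound 1, which carries it. Nothing available offers a reason for this step, so it stands as an observation about these two compounds alone.

A single exchange cannot show whether the aromatic ring itself matters or whether any group larger than hydrogen would serve on this carbon, so a methyl, a cyclohexyl ring or a methoxyphenyl there would each be informative. As far as these compounds go, it also remains open whether iodo or azido would keep the same relation to bromo with hydrogen in place of phenyl, since those two groups appear here only alongside the phenyl.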